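The source may hold more compounds than are shown below. What is called first, only, known or untested is meant among the compounds shown, and "the series" means these compounds.

Compound 2 `CC(Oc1ccccc1-c1ccccc1[N+](=O)[O-])C1=NCCN1` gives 1230 nM in an assay on CHO cells for displacement of a labelled ligand from Alpha-2C adrenergic receptor (Homo sapiens) (a lower number here means a stronger inhibitor, a higher number a weaker inhibitor), the highest of the two numbers at hand; compound 1 `Cc1ccc(-c2ccccc2OC(C)C2=NCCN2)cc1` gives 251 nM in this assay, a gap beyond the usual scatter. Compound 3 `CC(Oc1ccccc1-c1ccccc1O)C1=NCCN1` differs from compound 2 by hydroxy in place of nitro on an aromatic carbon. No step of this kind has been measured among these compounds, so the direction rests on judgement alone. The expected step is a 2.5-fold lower number from compound 2 to compound 3 (0.39 log units; beyond the scatter), a moderate move toward a lower number that may still sit within the scatter. The estimated value for compound 3 is 500 nM, with a range from 150 nM to 2000 nM.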

Compound 3, inhibition constant: 1620 nM
The estimate for compound 3 lay 3.2-fold (0.51 log units) below the measured number; the range from low to high includes it.
By their numbers in this assay, from the lowest: compound 1; then compounds 2 and 3 (each within the scatter of the next).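

In this assay, hydroxy in place of nitro on this aromatic carbon, ortho to a large group, gives a 1.3-fold higher number from compound 2 to compound 3 (0.12 log units; within the scatter), so the assay does not separate these two groups here, although hydroxy adds a hydrogen-bond donor. With 2-hydroxyphenyl in place of 4-methylphenyl, the step is a 6.5-fold higher number from compound 1 to compound 3 (0.81 log units; beyond the scatter), so the hydroxy compound stays well apart from compound 1. No measurement at hand accounts for either step.

Going by these compounds, whether an amine or a carboxylic acid on this carbon would behave like nitro and hydroxy remains open. So does whether the lower number of compound 1 belongs to its methyl group or to the absence of any group on this carbon.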